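Swapping thiophene for difluorophenyl on the side chain

The compounds below may be only part of what the source reports. "The series", "measured", "known", "first", "only" and "open" are said of these compounds alone.

In a functional assay on MCF7 cells (Homo sapiens) for cytotoxicity (a lower number here means a stronger inhibitor, a higher number a weaker inhibitor), the three measured compounds read as follows. Compound 1 `C=C/C=C\[C@H](C)[C@H](OC(N)=O)[C@@H](C)[C@H](O)[C@@H](C)C/C(C)=C\[C@H](C)[C@@H](O)[C@@H](C)/C=C\CCc1ccccc1` gives 560 nM. Compound 2 `C=C/C=C\[C@H](C)[C@H](OC(N)=O)[C@@H](C)[C@H](O)[C@@H](C)C/C(C)=C\[C@H](C)[C@@H](O)[C@@H](C)/C=C\CCc1ccsc1` gives 4000 nM. Compound 3 `C=C/C=C\[C@H](C)[C@H](OC(N)=O)[C@@H](C)[C@H](O)[C@@H](C)C/C(C)=C\[C@H](C)[C@@H](O)[C@@H](C)/C=C\CCc1cccc(F)c1` gives 500 nM.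

Compound 2 stands highest of the three, with the other two well separated from it: a 7.1-fold higher number from compound 1 to compound 2 (0.85 log units; beyond the scatter) and an 8.0-fold lower number from compound 2 to compound 3 (0.90 log units; beyond the scatter). Compound 4 `C=C/C=C\[C@H](C)[C@H](OC(N)=O)[C@@H](C)[C@H](O)[C@@H](C)C/C(C)=C\[C@H](C)[C@@H](O)[C@@H](C)/C=C\CCc1cc(F)cc(F)c1` differs from compound 2 by 3,5-difluorophenyl in place of thiophen-3-yl on a saturated chain carbon, two bonds along the chain from a double-bonded chain carbon. The step that bears on this most directly is an 8.0-fold lower number from compound 2 to compound 3 (0.90 log units; beyond the scatter), and the second fluoro looks nearly neutral because a 1.1-fold lower number from compound 1 to compound 3 (0.05 log units; within the scatter). For compound 4 a step of a 7.3-fold lower number from compound 2 to compound 4 (0.86 log units; beyond the scatter) in this assay is therefore expected, towards a lower number. Compound 4 is estimated at 550 nM, with a likely range from 250 nM to 1400 nM.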

Compound 4, half-maximal inhibitory concentration: 2000 nM
Estimate against measurement, compound 4: 3.6-fold (0.56 log units) below; measured number above the stated range.
By their numbers in this assay, from the lowest: compounds 3 and 1 (each within the scatter of the next); then compounds 4 and 2 (each within the scatter of the next).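

In this assay a second fluoro on the phenyl ring is not neutral at this position: adding it gives a 4.0-fold higher number from compound 3 to compound 4 (0.60 log units; beyond the scatter) and the 3,5-difluorophenyl group as a whole gives a 3.6-fold higher number from compound 1 to compound 4 (0.55 log units; beyond the scatter) on this chain. Against thiophen-3-yl the step is a 2.0-fold lower number from compound 2 to compound 4 (0.30 log units; within the scatter). So compound 4 groups with compound 2 rather than with compounds 1 and 3. Nothing among the data shown accounts for this. From the compounds shown here alone, how a 3,5-dichlorophenyl group, a pyridine ring or a longer chain would read at this place stays open.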